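A few compounds are considered here, and "the series" means these few. Any claim that something is new, unique, unknown or untested is made for them only; others in the source may bear on it.

Working notes on the series. Two compounds carry numbers in an in vitro assay on HEK-tsA201 cells for antagonist activity at Neuronal acetylcholine receptor; alpha3/beta4 (Homo sapiens), read by fluorescence and calcium flux (on this read-out lower numbers stand for stronger inhibition and higher numbers for weaker inhibition), so far. Compound 1 `C=CCOc1ccc(C(=O)Nc2cccc(Br)n2)cc1` gives 65500 nM in this assay. Among the compounds with values here, compound 2 `CCCOc1ccc(C(=O)Nc2cccc(Cl)n2)cc1` differs from compound 1 in the halogen on the core and in the alkoxy chain, and no step between them is computed here. For compound 2 this assay returns only a limit, > 100000 nM, so compound 2 stands at the weak end of the numbers shown, at the limit of > 100000 nM in this assay, at which 1 of the 2 values shown sits. Compound 3 `CCCOc1ccc(C(=O)Nc2cccc(Nc3ccc(Cl)cc3)n2)cc1` has not yet been measured in this assay. Compound 3 differs from compound 2 by (4-chlorophenyl)amino in place of chloro on an aromatic carbon. Since compound 2 gives only a limit, the step is expected to run toward stronger inhibition, with the change an at least 2.0-fold lower number from compound 2 to compound 3 (0.30 log units; that floor lies within the scatter) estimated to exceed the usual scatter. Compound 3 is estimated at 50000 nM in this assay, within a range from 10000 nM to 200000 nM, and a further limit remains plausible.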

Compound 3, half-maximal inhibitory concentration: > 100000 nM
Compound 3 was reported as a limit; the forecaster's own chance of this, stated with the estimate: 45%; at least 2.0-fold (0.30 log units) between middle value and limit.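

Within the data shown here, compound 2 and compound 3 both return only a limit in this assay, so no step between them can be read: the limit of > 100000 nM in this assay, at which 2 of the 3 values shown sit.
The compounds shown leave open whether (4-chlorophenyl)amino in place of chloro changes inhibition at all, and how far past the limit either compound lies.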